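Swapping Methoxy for Methyl: Expected Cytotoxicity in BJ Cells

A few compounds are considered here, and "the series" means these few. Any claim that something is new, unique, unknown or untested is made for them only; others in the source may bear on it.

Compound 1, `COc1ccc(NC(=O)Nc2cc(C)nc3ccccc23)cc1`: > 25000 nM
Compound 2, `COc1ccc(NC(=O)Nc2cc(C)nc3ccccc23)cc1F`: 26000 nM

In an ADME assay on BJ cells (Homo sapiens) for cytotoxicity, with a stated time of 72 h (a higher number here means that more compound is needed for the effect, a lower number that less compound is needed), compound 1 gives > 25000 nM, which is a limit of the assay rather than a number. Compound 2 gives 26000 nM in this assay. The step that the limit leaves unreadable from compound 1 to compound 2 cannot be read because of the limit of > 25000 nM in this assay, at which 1 of the 2 values shown sits. Compound 3, `Cc1ccc(NC(=O)Nc2cc(C)nc3ccccc23)cc1`, differs from compound 1 by methyl in place of methoxy on an aromatic carbon. Going by the values given here, no measured step mirrors this change, and the only step at hand is unreadable, so no shift beyond the scatter is expected. Compound 3 is therefore estimated at 25000 nM, expected to lie between 10000 nM and 60000 nM. The expected step is a number no higher from compound 1 to compound 3 (the limit leaves the size open).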

Compound 3, half-maximal effective concentration: > 25000 nM
Compound 3: a limit, no number; the forecaster's own chance of this, stated with the estimate: 60%; the middle value lies on the limit itself.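

Compound 1 and compound 3 both give a limit rather than a number in this assay, so no step can be read between them: the limit of > 25000 nM in this assay, at which 2 of the 3 values shown sit.

Going by these compounds, whether methyl in place of methoxy changes the value at all remains open.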